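The source may report more compounds than this note shows. Statements on the series, on what has been measured and on what is new or still open speak of the compounds shown alone.

In a functional assay on HepG2 cells (Homo sapiens) for cytotoxicity, read by MTT assay, with a stated time of 24 h (on this read-out lower numbers stand for stronger inhibition and higher numbers for weaker inhibition), compound 1 (`COc1cc(/C=C2\CN(C)C/C(=C\c3ccccc3F)C2=O)cc(OC)c1`) gives 1240 nM, compound 2 (`CN1C/C(=C\c2ccc(C#N)cc2)C(=O)/C(=C/c2ccccc2F)C1`) gives 590 nM and compound 3 (`COc1cc(/C=C2\CN(C)C/C(=C\c3cc(OC)c(OC)c(OC)c3)C2=O)cc(OC)c1`) gives 890 nM. Compound 3 therefore lies within the usual scatter of both compound 1 and compound 2, so its place among these three numbers carries little weight.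

Compound 4 (`COc1cc(/C=C2\CN(C)C/C(=C\c3ccc(Br)cc3)C2=O)cc(OC)c1OC`) differs from compound 3 in one place, a double-bonded chain carbon bound to a double-bonded ring carbon, where 4-bromophenyl stands in place of 3,5-dimethoxyphenyl (4-bromophenyl in place of 3,5-dimethoxyphenyl on a double-bonded chain carbon bound to a double-bonded ring carbon). Going by the values given here, no pair of measured compounds shows this swap on its own, so the expectation rests on indirect evidence. In this assay no step beyond the scatter is expected, given that compound 2, which has no methoxy group, gives 590 nM. The expected change is a 1.3-fold lower number from compound 3 to compound 4 (0.10 log units; within the scatter). For compound 4 the estimated value is 700 nM, with an expected range of 300 nM to 1600 nM.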

Compound 4, half-maximal inhibitory concentration: 6800 nM
Compound 4: middle estimate off by 9.7-fold (0.99 log units), on the low side, outside the stated range (above it).
By their numbers in this assay, from the lowest: compounds 2, 3 and 1 (each within the scatter of the next, the first and the last beyond it); then compound 4.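

In this assay, the swap at the one place of difference gives a 7.6-fold higher number from compound 3 to compound 4 (0.88 log units; beyond the scatter), a step beyond the scatter. Going by these compounds alone, this is the first single change that can be read at this place, and it shows that the group there can strongly shift the number, here towards weaker inhibition. Nothing at hand explains why the number rises.

As far as these compounds go, the swap removes two methoxy groups and brings in a bromine at the same time, so the share of each in the step remains unknown. A plain phenyl or a 4-chlorophenyl at this place would help to separate the loss of the methoxy groups from the arrival of the halogen.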